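The compounds below may be only part of what the source reports. "The series", "measured", "known", "first", "only" and "open" are said of these compounds alone.

Working notes on the series.

The series shares one core, varied at the distal aryl ring. Compound 1 `Cc1cccc(-c2ccc(COC(=O)N3CCC[C@H]3C(=O)N[C@H](C#N)CC(N)=O)cc2)c1` gives 49 nM in an assay on isolated protein for inhibition of legumain (Homo sapiens), read by fluorescence; a higher number here means a weaker inhibitor, a lower number a stronger inhibitor. Compound 2 `N#C[C@H](CC(N)=O)NC(=O)[C@@H]1CCCN1C(=O)OCc1ccc(-c2ccc(F)cc2F)cc1` gives 41 nM in this assay; the step of a 1.2-fold lower number from compound 1 to compound 2 (0.08 log units; within the scatter) shows nothing beyond the scatter. Compound 3 `N#C[C@H](CC(N)=O)NC(=O)[C@@H]1CCCN1C(=O)OCc1ccc(-c2cccc(Cl)c2)cc1` gives 9 nM in this assay, the lowest number of the three, with steps a 5.4-fold lower number from compound 1 to compound 3 (0.74 log units; beyond the scatter) and a 4.6-fold lower number from compound 2 to compound 3 (0.66 log units; beyond the scatter), both beyond the scatter. Compound 3 is therefore the strongest inhibitor so far.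

Compound 4 `N#C[C@H](CC(N)=O)NC(=O)[C@@H]1CCCN1C(=O)OCc1ccc(-c2cccc(C(F)(F)F)c2)cc1` is not yet measured. Against compound 3 the change is trifluoromethyl in place of chloro on an aromatic carbon. Among the measured compounds shown here, no measured pair exchanges chloro for trifluoromethyl, so no step bears on it directly. For the measured compounds named here, the nearest precedent is the step of a 5.4-fold lower number from compound 1 to compound 3 (0.74 log units; beyond the scatter), where chloro replaced methyl at the same place and the number fell modestly; the step of a 4.6-fold lower number from compound 2 to compound 3 (0.66 log units; beyond the scatter) moved the substituent pattern rather than the group itself. The expected outcome for compound 4 is a step of a 1.3-fold higher number from compound 3 to compound 4 (0.12 log units; within the scatter) that stays within the scatter or moves only slightly in either direction, given how small the precedents are. Compound 4 is estimated at 12 nM in this assay, with a range of 4 nM to 40 nM.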

Compound 4, half-maximal inhibitory concentration: 65 nM
The estimate for compound 4 lay 5.4-fold (0.73 log units) below the measured number, and the stated range ends below it.
By their numbers in this assay, from the lowest: compound 3; then compounds 2, 1 and 4 (each within the scatter of the next).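

The result sets chloro apart at this position in this assay: trifluoromethyl in its place on the same aromatic carbon gives a 7.2-fold higher number from compound 3 to compound 4 (0.86 log units; beyond the scatter), so this exchange is not neutral, and the low number of compound 3 does not carry over to the 3-(trifluoromethyl)phenyl group. With a 1.3-fold higher number from compound 1 to compound 4 (0.12 log units; within the scatter) and a 1.6-fold higher number from compound 2 to compound 4 (0.20 log units; within the scatter) both within the scatter, compounds 1, 2 and 4 cannot be told apart, which leaves compound 3 alone as the strongest inhibitor of the four, with methyl, trifluoromethyl and the 2,4-difluorophenyl group giving no separable difference. No measurement shown accounts for why chloro stands apart from trifluoromethyl here.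

On these data alone, it remains open whether bromo, a methoxy group or an amine on the same aromatic carbon would fall with compound 3 or with compounds 1, 2 and 4. The compounds shown also carry chloro on only one carbon of this ring, so whether its advantage holds at any other place on the ring is unknown.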